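The source may report more compounds than this note shows. Statements on the series, on what has been measured and on what is new or still open speak of the compounds shown alone.

Compound 3 `O=C(Nc1cccnc1)c1cc(C(F)(F)F)ccc1OCc1ccccc1` gives 12.6 nM in an assay on Sf9 cells for inhibition of Leucine-rich repeat serine/threonine-protein kinase 2 (Homo sapiens), read by TR-FRET, with stated times of 30 min and 2 h (on this read-out higher numbers stand for weaker inhibition and lower numbers for stronger inhibition), level with compound 1 `O=C(Nc1cccc(Cl)c1)c1cc(C(F)(F)F)ccc1OCc1ccc(F)cc1`, which gives 12.6 nM; the two share the lowest value of the three compounds measured. Compound 2 `O=C(Nc1ccnnc1)c1cc(N2CCNCC2)ccc1OCc1ccccc1` gives 15.9 nM in this assay, and its gap to compound 3 lies within the scatter, so no order among the three can be stated. Compound 4 `O=C(Nc1cccc(Cl)c1)c1cc(C(F)(F)F)ccc1OCc1ccccc1` has not been measured. It differs from compound 3 by 3-chlorophenyl in place of pyridin-3-yl on an amide-type nitrogen. Compound 1 already carries a 3-chlorophenyl on the amide-type nitrogen and matches compound 3, and as compound 1 gives 12.6 nM, compound 4 is expected to sit alongside both, with an estimated step of a 1.1-fold lower number from compound 3 to compound 4 (0.02 log units; within the scatter), none beyond the scatter. Compound 4 is therefore estimated at 12 nM, within a range from 6 nM to 25 nM.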

Compound 4, half-maximal inhibitory concentration in the Leucine-rich repeat serine/threonine-protein kinase 2 assay: 25.1 nM
Compound 4: the middle estimate sits 2.1-fold (0.32 log units) below what was measured, and the stated range ends below it.
By their numbers in the Leucine-rich repeat serine/threonine-protein kinase 2 assay, from the lowest: compounds 1, 3, 2 and 4 (each within the scatter of the next).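

The change from pyridin-3-yl to 3-chlorophenyl on the amide-type nitrogen stays within the scatter in the Leucine-rich repeat serine/threonine-protein kinase 2 assay, at a 2.0-fold higher number from compound 3 to compound 4 (0.30 log units; within the scatter), and hydrogen in place of fluoro on an aromatic carbon does likewise, at a 2.0-fold higher number from compound 1 to compound 4 (0.30 log units; within the scatter). In a physicochemical assay for solubility, measured as kinetic solubility (on this read-out higher numbers stand for higher solubility and lower numbers for lower solubility), compound 3 gives < 1000 nM, which is a limit of the assay and not a number: the limit of < 1000 nM in the physicochemical assay, at which 1 of the 2 values shown sits. In the physicochemical assay compound 4 gives 7000 nM, and the change on the amide-type nitrogen reads an at least 7.0-fold higher number from compound 3 to compound 4 (0.84 log units; beyond the scatter), so here it goes beyond the scatter.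

As far as these compounds go, what an amine or a carboxylic acid on the aromatic ring at this nitrogen would give in the Leucine-rich repeat serine/threonine-protein kinase 2 assay and the physicochemical assay remains open.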